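Swapping methoxy for bromo on a shared amide scaffold

The source may hold more compounds than are shown below. What is called first, only, known or untested is meant among the compounds shown, and "the series" means these compounds.

Measured so far:
compound 1 `O=C(Nc1ccc(Oc2ccnc3[nH]ccc23)cc1)c1nccc(-c2cccc(Cl)c2)n1`: 10200 nM
compound 2 `COc1ccc(-c2ccnc(C(=O)Nc3ccc(Oc4ccnc5[nH]ccc45)cc3)n2)cc1`: 12400 nM
compound 3 `COc1ccc(-c2cc(C(=O)Nc3ccc(Oc4ccnc5[nH]ccc45)cc3)ncn2)cc1`: 4450 nM

In a functional assay on MCF7 cells (Homo sapiens) for cytotoxicity, read by MTT assay, with a stated time of 72 h (on this read-out lower numbers stand for stronger inhibition and higher numbers for weaker inhibition), compound 3 gives 4450 nM, the lowest number of the three. Compound 1 gives 10200 nM and compound 2 gives 12400 nM, both beyond the scatter above compound 3. Compound 4 `O=C(Nc1ccc(Oc2ccnc3[nH]ccc23)cc1)c1cc(-c2ccc(Br)cc2)ncn1` differs from compound 3 by bromo in place of methoxy on an aromatic carbon. Within the data shown here, the only measured step that exchanges a halogen-bearing phenyl for a methoxy-bearing one is a 1.2-fold higher number from compound 1 to compound 2 (0.08 log units; within the scatter), and it stayed within the scatter, though that step changed more than one feature at once. Going the other way, from methoxy back to a halogen, the expected step is therefore small, a 1.1-fold higher number from compound 3 to compound 4 (0.05 log units; within the scatter), within the scatter. For compound 4 the estimate in this assay is 5000 nM, with a range from 2000 nM to 12000 nM.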

Compound 4, half-maximal inhibitory concentration: 3840 nM
For compound 4 the middle estimate is 1.3-fold (0.11 log units) above the measured one; the range from low to high includes it.
By their numbers in this assay, from the lowest: compounds 4 and 3 (each within the scatter of the next); then compounds 1 and 2 (each within the scatter of the next).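

In this assay, bromo in place of methoxy gives a 1.2-fold lower number from compound 3 to compound 4 (0.06 log units; within the scatter), a swap made at one fixed place, para to a large group, with nothing else altered. Among these compounds, on this read-out, therefore, these two groups cannot be told apart at this position, which the earlier compounds could not show with a change this clean. Nothing measured here explains why they read alike. Still open, going by these compounds, is whether an amine or a carboxylic acid at this position would give a clearly different number, and whether bromo and methoxy also match on the core of compound 2.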